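Swapping Nitro for Trifluoromethyl on a Sugar-Derived Acetal

The source may report more compounds than this note shows. Statements on the series, on what has been measured and on what is new or still open speak of the compounds shown alone.

Measured compounds:
- compound 1, `C=CC[C@@H]1O[C@@H]2CO[C@@H](c3ccccc3)O[C@H]2[C@H](OC)[C@H]1OC`: "not determined" (no result reported) in a functional assay on HEL cells (Homo sapiens) for cytotoxicity; on this read-out higher numbers stand for lower toxicity in this test and lower numbers for higher toxicity in this test
- compound 2, `O=[N+]([O-])c1ccc([C@@H]2OC[C@H]3O[C@@H](c4ccccc4)[C@H](O)[C@@H](O)[C@@H]3O2)cc1`: 50 ug/mL

Two compounds share the fused bicyclic core carrying a phenyl group and an aromatic acetal. Compound 1 bears an allyl group and two methyl ethers, and in this assay compound 1 has "not determined" (no result reported). Compound 2 carries two free hydroxyl groups and a nitro group on its aromatic acetal, and in this assay compound 2 gives 50 ug/mL. For the measured compounds named here, that is the only number in hand, so compound 2 cannot be placed relative to any other compound, and no step between measured compounds is available.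

Compound 3, `O[C@@H]1[C@@H](O)[C@H](c2ccccc2)O[C@@H]2CO[C@@H](c3ccc(C(F)(F)F)cc3)O[C@@H]12`, differs from compound 2 in one spot: trifluoromethyl in place of nitro on an aromatic carbon. Going by the values given here, with no measured step to lean on, the expected step from compound 2 to compound 3 is no change at the digits printed from compound 2 to compound 3 (within the scatter), which is within the usual scatter in either direction. Compound 3 is therefore expected to show a minimum cytotoxic concentration of about 50 ug/mL, with a plausible range from 25 ug/mL to 100 ug/mL.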

Compound 3, minimum cytotoxic concentration: 400 ug/mL
Estimate against measurement, compound 3: 8.0-fold (0.90 log units) below; the measured number lies above the stated range.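

In this assay, trifluoromethyl in place of nitro on an aromatic carbon, para to a large group, gives an 8.0-fold higher number from compound 2 to compound 3 (0.90 log units; beyond the scatter), so this change moves the read-out toward lower toxicity in this test. For the compounds shown here, with a single number in hand, the earlier compounds could not show whether this place on the aromatic ring mattered at all; this pair shows that what sits there can change the minimum cytotoxic concentration, and that of these two compounds the one carrying nitro is the more toxic in this test. The data shown do not indicate which feature of the two groups lies behind the shift.

On these data alone, what an amine, a carboxylic acid or a simple chlorine at this same place would do to the read-out remains open, since two groups at one position give a single comparison and no trend. Compound 1, with its allyl group and two methyl ethers, has no number to compare, so whether the free hydroxyl groups of compound 2 and compound 3 play any part in this assay also stays unanswered.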